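Shortening the Sulfonyl Side Chain of Compound 1

This account rests on a few compounds, and the source may have more. Where it says the series, first, only, none or still open, it means among the compounds named here.

In a physicochemical assay for lipophilicity (on this read-out higher numbers stand for higher lipophilicity and lower numbers for lower lipophilicity), compound 1 `CC(C)(c1cc([C@@]23CCOC[C@@H]2C3)nc(-c2cccc(O)c2)n1)S(C)(=O)=O` gives 4.8, and its mirror image, compound 2 `CC(C)(c1cc([C@]23CCOC[C@H]2C3)nc(-c2cccc(O)c2)n1)S(C)(=O)=O`, gives 4.8, so the two stand level. Compound 3 `CS(=O)(=O)Cc1cc([C@@]23CCOC[C@@H]2C3)nc(-c2cccc(O)c2)n1` shares the core of compound 1 but carries (methylsulfonyl)methyl in place of 1-methyl-1-(methylsulfonyl)ethyl on an aromatic carbon. Among the measured compounds shown here, the only measured step, no change at the digits printed from compound 1 to compound 2 (within the scatter), reflects (the fact that compounds 1 and 2 differ only in the configuration as drawn), so it gives no direct measure for a change of side chain. The expectation therefore rests on the structural change alone, in which the entering group has fewer carbons than the one it replaces. A clear downward step is expected in this assay, estimated as a number 0.70 log units lower from compound 1 to compound 3 (beyond the scatter). Compound 3 is thus estimated at 4.1, with an expected range of 3.7 to 4.5.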

Compound 3, partition coefficient: 3.7
Estimate against measurement, compound 3: 0.40 log units above, within the range that was stated.
By their numbers in this assay, from the lowest: compound 3; then compounds 1 and 2 (each within the scatter of the next).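

Compounds 1 and 2 showed only that mirror-image configurations stand level, so compound 3 gives the first measured effect of changing the group at this aromatic carbon, next to the ring nitrogen. In this assay, the change to (methylsulfonyl)methyl from 1-methyl-1-(methylsulfonyl)ethyl gives a number 1.10 log units lower from compound 1 to compound 3 (beyond the scatter), a large step for so small a change. The two groups match in oxygen, sulfur and hydrogen-bond acceptors and differ in carbon count, but nothing measured here accounts for the size of the step.

The compounds shown leave open whether a 1-(methylsulfonyl)ethyl chain would fall between compound 1 and compound 3 in this assay. They also leave open how an amine or a carboxylic acid on this aromatic carbon would read there.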